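The source may hold more compounds than are shown below. What is called first, only, known or untested is meant among the compounds shown, and "the series" means these compounds.

Measured compounds:
Compound 1, `CC(C)c1ccc(-c2nc(SCc3cn(CC(=O)NC(=O)Nc4ccccn4)nn3)nc(Nc3ccc(F)cc3)c2C#N)cc1`, gives 7250 nM in a functional assay on B16-F10 cells (Mus musculus) for inhibition, read by MTT assay, with a stated time of 72 h; a higher number here means a weaker inhibitor, a lower number a stronger inhibitor.
Compound 2, `CC(C)c1ccc(-c2nc(SCc3cn(CC(=O)NC(=O)Nc4ccccn4)nn3)nc(Nc3ccc(Cl)cc3)c2C#N)cc1`, gives 860 nM in this assay.
Compound 3, `CC(C)c1ccc(-c2nc(SCc3cn(CC(=O)NC(=O)Nc4ccccn4)nn3)nc(Nc3cccc(Cl)c3)c2C#N)cc1`, gives 1130 nM in this assay.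

Compound 2 has the lowest number of the three in this assay. Compound 3 sits close to it, with a 1.3-fold higher number from compound 2 to compound 3 (0.12 log units; within the scatter), so the two cannot be told apart. Compound 1 stands clearly apart: the change from fluoro to chloro gave an 8.4-fold lower number from compound 1 to compound 2 (0.93 log units; beyond the scatter), and the change from 4-fluorophenyl to 3-chlorophenyl gave a 6.4-fold lower number from compound 1 to compound 3 (0.81 log units; beyond the scatter).

Compound 4, `CC(C)c1ccc(-c2nc(SCc3cn(CC(=O)NC(=O)Nc4ccccn4)nn3)nc(Nc3ccccc3F)c2C#N)cc1`, differs from compound 2 by 2-fluorophenyl in place of 4-chlorophenyl on a nitrogen on an aromatic ring. This change does two things at once: it swaps chloro for fluoro, and it moves the halogen to a new position on the phenyl ring. Among the measured steps, the fluoro-to-chloro swap was the one that mattered, whereas moving chloro from one position to another changed little. The swap back to fluoro therefore suggests a higher number, while the new position is not covered by any measured pair. Compound 4 is expected to come in well above compound 2, with an estimated step of a 4.7-fold higher number from compound 2 to compound 4 (0.67 log units; beyond the scatter). The estimate for compound 4 is 4000 nM, with a range from 1400 nM to 12000 nM.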

Compound 4, half-maximal inhibitory concentration: 8380 nM
Estimate against measurement, compound 4: 2.1-fold (0.32 log units) below; low and high end bracket the measured number.
By their numbers in this assay, from the lowest: compounds 2 and 3 (each within the scatter of the next); then compounds 1 and 4 (each within the scatter of the next).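

The new fluoro compound shows that the 2-fluorophenyl group gives up the gain seen with either chloro group in this assay: the change from 4-chlorophenyl gives a 9.7-fold higher number from compound 2 to compound 4 (0.99 log units; beyond the scatter), and the change from 3-chlorophenyl gives a 7.4-fold higher number from compound 3 to compound 4 (0.87 log units; beyond the scatter). The earlier compounds shown here could not show whether moving fluoro around the phenyl ring would matter, and here the change from 4-fluorophenyl to 2-fluorophenyl gives a 1.2-fold higher number from compound 1 to compound 4 (0.06 log units; within the scatter), so the two fluoro compounds cannot be told apart, just as the two chloro compounds could not. Across these four compounds, with none going against it, the choice of halogen separates the numbers while its place on the ring does not, though no measurement available here offers an explanation for that split.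

The compounds shown leave open where a 2-chlorophenyl group would fall, and it would test this split at the one ring position so far seen only with fluoro. They also leave open whether a bromo group, a methoxy group or a plain phenyl ring would sit with the chloro pair, with the fluoro pair, or apart from both.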